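Carboxamide in Place of Thioether on the Shared Core

The source may hold more compounds than are shown below. What is called first, only, known or untested is meant among the compounds shown, and "the series" means these compounds.

Compound 1, `CC(C)Cn1c(=O)n(C)c(=O)c2[nH]c(=O)c(Cc3cccc4ccccc34)nc21`: in a functional assay on Raji cells (Homo sapiens) for inhibition, read by MTT assay, with a stated time of 96 h (on this read-out higher numbers stand for an effect only at larger amounts of compound and lower numbers for an effect already at smaller amounts), compound 1 gives > 10000 nM, which is a limit of the assay.
Compound 2, `CC(C)Cn1c(=O)n(C)c(=O)c2c1nc(Cc1cccc3ccccc13)c(=O)n2CCCCCO`: compound 2 gives 1420 nM.
Compound 3, `CC(C)Cn1c(=O)n(C)c(=O)c2nc(SCCO)c(Cc3cccc4ccccc34)nc21`: compound 3 gives 2850 nM.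

Compound 3 carries the highest number of the two that are actual values, but its nearest neighbour is compound 2 and the gap between them is within the scatter, so no order between the two can be claimed. Within the data shown here, the only step measured so far is an at least 7.0-fold lower number from compound 1 to compound 2 (0.84 log units; beyond the scatter); it shows that attaching a hydroxyalkyl chain to the core of compound 1 brings the number down from the limit of > 10000 nM in this assay, at which 1 of the 3 values shown sits, into the measurable range.

Compound 4, `CC(C)Cn1c(=O)n(C)c(=O)c2nc(C(=O)NCCCO)c(Cc3cccc4ccccc34)nc21`, is obtained from compound 3 by the change ((3-hydroxypropyl)carbamoyl in place of (2-hydroxyethyl)sulfanyl on an aromatic carbon). Among the measured compounds shown here, no measured step matches this exchange: the step from compound 1 to compound 2 concerns a hydrogen on an aromatic nitrogen and not the replacement of one hydroxyalkyl-bearing group by another. Compound 2 and compound 3 both carry a hydroxyalkyl chain on the core and sit within the scatter of each other, so the expectation for compound 4 is a step of no more than the scatter in this assay, in either direction, that is a 1.1-fold higher number from compound 3 to compound 4 (0.02 log units; within the scatter). Compound 4 is therefore estimated at 3000 nM, with a range from 1000 nM to 9000 nM.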

Compound 4, half-maximal effective concentration: > 10000 nM
Compound 4: a limit, no number (the forecaster's own chance of this, stated with the estimate: 15%); at least 3.3-fold (0.52 log units) between middle value and limit.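

In this assay, placing (3-hydroxypropyl)carbamoyl instead of (2-hydroxyethyl)sulfanyl on this aromatic carbon, next to the ring nitrogen, gives an at least 3.5-fold higher number from compound 3 to compound 4 (0.54 log units; beyond the scatter). Both groups carry a hydroxyl at the end of their chain, so this pair shows what the earlier step from compound 1 to compound 2 could not: at this position, a hydroxyalkyl chain does not by itself keep the number in the measurable range, and the way the chain is attached or its length matters. Compound 4, like compound 1, stands at a limit and not at a number, so the true size of the step stays unknown: the limit of > 10000 nM in this assay, at which 2 of the 4 values shown sit.

The exchange alters the link to the ring and the chain length at once, so the compounds shown leave open which of the two carries the step; a (2-hydroxyethyl)carbamoyl or a (3-hydroxypropyl)sulfanyl group on this carbon would separate them. Also open, on these data alone, is how a thioether or carboxamide chain ending in an amine or a carboxylic acid instead of a hydroxyl would read in this assay.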